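This account rests on a few compounds, and the source may have more. Where it says the series, first, only, none or still open, it means among the compounds named here.

Measured compounds:
Compound 1, `CCOC(=O)C(=O)CC(=O)/C=C/c1cn(-c2ccc(O)cc2)c2ccccc12`: in an assay on isolated protein for inhibition of DNA nucleotidylexotransferase (Homo sapiens), read by scintillation counting, with a stated time of 10 min (on this read-out higher numbers stand for weaker inhibition and lower numbers for stronger inhibition), compound 1 gives > 40 uM, which is a limit of the assay rather than a number.
Compound 2, `CCOC(=O)C(=O)CC(=O)/C=C/c1cn(Cc2ccccc2)c2ccccc12`: in this assay compound 2 gives > 40 uM, again a limit.
Compound 3, `O=C(/C=C/c1cn(Cc2ccccc2)c2ccccc12)CC(=O)C(=O)O`: in this assay compound 3 gives 7.9 uM.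

For the measured compounds named here, compound 3 therefore holds the only real number among the three; the other two values sit at the limit of > 40 uM in this assay, at which 2 of the 3 values shown sit. The change from compound 1 to compound 2 swaps the group on the aromatic nitrogen, but its size is a step that the two limits leave unreadable from compound 1 to compound 2. The change from compound 2 to compound 3, ethyl ester to free acid, gives an at least 5.0-fold lower number from compound 2 to compound 3 (0.70 log units; beyond the scatter).

Compound 4, `CN(C)C(=O)Cn1cc(/C=C/C(=O)CC(=O)C(=O)O)c2ccccc21`, differs from compound 3 by dimethylcarbamoyl in place of phenyl on a saturated chain carbon bound to an aromatic nitrogen. Going by the values given here, neither measured step reads on a change at this position: the one step on the aromatic nitrogen is unreadable, and the other concerns the acid end. Without guidance, the expectation is a change of about a 1.3-fold higher number from compound 3 to compound 4 (0.10 log units; within the scatter), no larger than the scatter. Compound 4 is thus estimated at 10 uM, with a range from 3 uM to 35 uM.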

Compound 4, concentration for 50% inhibition: 8.9 uM
The estimate for compound 4 lay 1.1-fold (0.05 log units) above the measured number; low and high end bracket the measured number.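

In this assay, putting dimethylcarbamoyl in place of phenyl on a saturated chain carbon bound to an aromatic nitrogen gives a 1.1-fold higher number from compound 3 to compound 4 (0.05 log units; within the scatter). For the compounds shown here, with the free acid kept, this is the first readable step for a change on this side of the molecule, and it shows that a six-membered aromatic ring is not required here: a group with no ring and one hydrogen-bond acceptor serves equally well in this read-out. The earlier step on the aromatic nitrogen, from compound 1 to compound 2, cannot be read, because both of its values are limits of the assay: the limit of > 40 uM in this assay, at which 2 of the 4 values shown sit.

Going by these compounds, it remains open whether a basic amine, a carboxylic acid or a longer chain at this place would give a similar value. The compounds shown also leave open how a simple methyl group on the aromatic nitrogen would compare.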